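Chloro in Place of Trifluoromethyl: Expected Shift in Potency

A few compounds are considered here, and "the series" means these few. Any claim that something is new, unique, unknown or untested is made for them only; others in the source may bear on it.

Compound 1 `Oc1nc2nonc2nc1Nc1ccc(OCc2ccccc2)cc1`: 2400 nM
Compound 2 `Oc1nc2nonc2nc1Nc1ccc(S(F)(F)(F)(F)F)cc1`: 3900 nM
Compound 3 `Oc1nc2nonc2nc1Nc1ccc(C(F)(F)F)cc1`: 10400 nM

In an assay on mitochondria from L6 cells (Rattus norvegicus) for activation, with a stated time of 90 min (a higher number here means that more compound is needed for the effect, a lower number that less compound is needed), compound 3 stands at the highest of the three numbers. The steps toward it, a 4.3-fold higher number from compound 1 to compound 3 (0.64 log units; beyond the scatter) and a 2.7-fold higher number from compound 2 to compound 3 (0.43 log units; beyond the scatter), both lie beyond the scatter. Compound 4 `Oc1nc2nonc2nc1Nc1ccc(Cl)cc1` differs from compound 3 by chloro in place of trifluoromethyl on an aromatic carbon. The two steps ending at compound 3 each put a smaller group where a larger one stood, and each raised the number, as a 4.3-fold higher number from compound 1 to compound 3 (0.64 log units; beyond the scatter) and a 2.7-fold higher number from compound 2 to compound 3 (0.43 log units; beyond the scatter) show. Chloro is smaller again than trifluoromethyl. Within the data shown here, compound 4 is therefore expected to give a modestly higher number in this assay, a 1.5-fold higher number from compound 3 to compound 4 (0.19 log units; within the scatter), though only two steps support this reading. The estimate for compound 4 is 16000 nM, with a range from 6000 nM to 40000 nM.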

Compound 4, half-maximal effective concentration: 11700 nM
Compound 4: the middle estimate sits 1.4-fold (0.14 log units) above what was measured; the measured number falls inside the stated range.
By their numbers in this assay, from the lowest: compounds 1 and 2 (each within the scatter of the next); then compounds 3 and 4 (each within the scatter of the next).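

In this assay, exchanging trifluoromethyl for chloro leaves the number within the scatter (a 1.1-fold higher number from compound 3 to compound 4 (0.05 log units; within the scatter)), so at this position a further cut in group size brought no step beyond the scatter. Chloro stays clearly apart from the two larger groups (a 3.0-fold higher number from compound 2 to compound 4 (0.48 log units; beyond the scatter); a 4.9-fold higher number from compound 1 to compound 4 (0.69 log units; beyond the scatter)), both steps lying beyond the scatter, much as trifluoromethyl does. No supporting evidence bears on why these two groups cannot be told apart. The compounds shown leave open how an amine, a carboxylic acid or a longer chain would read at this position.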